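Swapping isopropyl for fluoro on the aromatic ring

The compounds below may be only part of what the source reports. "The series", "measured", "known", "first", "only" and "open" are said of these compounds alone.

Compound 1 `Cc1ccc(C(=O)CC(SCC(=O)O)C(=O)O)cc1`: 17300 nM
Compound 2 `CCc1ccc(C(=O)CC(SCC(=O)O)C(=O)O)cc1`: 4790 nM
Compound 3 `CC(C)c1ccc(C(=O)CC(SCC(=O)O)C(=O)O)cc1`: 3330 nM

In a functional assay on HeLa cells (Homo sapiens) (on this read-out lower numbers stand for stronger inhibition and higher numbers for weaker inhibition), compound 3 gives 3330 nM, which is within the scatter of compound 2, as a 1.4-fold lower number from compound 2 to compound 3 (0.16 log units; within the scatter) shows. Compound 4 `O=C(O)CSC(CC(=O)c1ccc(F)cc1)C(=O)O` differs from it by fluoro in place of isopropyl on an aromatic carbon. Two measured steps change the group at this place: a 3.6-fold lower number from compound 1 to compound 2 (0.56 log units; beyond the scatter) and a 5.2-fold lower number from compound 1 to compound 3 (0.72 log units; beyond the scatter). Both are modest but beyond the scatter. For the measured compounds named here, no fluoro compound has been measured, so this is only a guide. Undoing the last of these steps suggests a modest move to a higher number in this assay. The expected change is a 5.4-fold higher number from compound 3 to compound 4 (0.73 log units; beyond the scatter). For compound 4 the estimated value is 18000 nM, with an expected range of 7000 nM to 50000 nM.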

Compound 4, half-maximal inhibitory concentration: 20700 nM
Beside the measured number, compound 4's estimate is 1.2-fold (0.06 log units) below it, within the range that was stated.
By their numbers in this assay, from the lowest: compounds 3 and 2 (each within the scatter of the next); then compounds 1 and 4 (each within the scatter of the next).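

Replacing the larger groups with fluoro at this aromatic carbon gives higher numbers in this assay, with a 6.2-fold higher number from compound 3 to compound 4 (0.79 log units; beyond the scatter) and a 4.3-fold higher number from compound 2 to compound 4 (0.64 log units; beyond the scatter) on the same read-out. Fluoro and methyl cannot be told apart here, as a 1.2-fold higher number from compound 1 to compound 4 (0.08 log units; within the scatter) shows. Compounds 1, 2 and 3 carry only carbon groups at this place, so compound 4 adds a non-carbon group, and it sits level with methyl.

Nothing available explains this result. Going by these compounds, whether a chloro group, a methoxy group or an amine at this place would match fluoro or isopropyl remains open.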